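The source may report more compounds than this note shows. Statements on the series, on what has been measured and on what is new or still open speak of the compounds shown alone.

Measured compounds:
- compound 1, `Fc1ccc(Oc2ccc3c(NCCCNCc4ccco4)ccnc3c2)cc1`: in an ADME assay for permeability, using PAMPA, with a stated time of 30 min, at pH 7.4 (a lower number here means that the compound crosses the layer more slowly, a higher number that the compound crosses the layer faster), compound 1 gives 317 10^-6 cm/s
- compound 2, `COc1cccc(CNCCCNc2ccnc3cc(Cc4ccc(C#N)cc4)ccc23)c1O`: compound 2 gives 23 10^-6 cm/s
- compound 3, `CC(C)(C)c1ccc(-c2ccc3c(NCCCNCc4ccco4)ccnc3c2)cc1`: compound 3 gives 237 10^-6 cm/s

Compound 3 stands second highest of the three numbers. Going by the values given here, its nearest neighbour is compound 1, and the only single-point step so far, a 1.3-fold lower number from compound 1 to compound 3 (0.13 log units; within the scatter), is within the scatter. Compound 2 is the furthest, with a number well beyond the scatter below compound 3.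

Compound 4, `N#Cc1ccc(Cc2ccc3c(NCCCNCc4ccco4)ccnc3c2)cc1`, is not yet measured. Its change from compound 3: 4-cyanobenzyl in place of 4-(tert-butyl)phenyl on an aromatic carbon

Among the compounds with values here, the step from compound 1 to compound 3 is the one measured change at this aromatic carbon, and it showed no shift beyond the scatter; it does not involve the 4-cyanobenzyl group. Within the data shown here, compound 2 carries the same 4-cyanobenzyl group and gives 23 10^-6 cm/s, but it also differs from compound 4 in the amine side chain, so no step between them is available and its number is only a pointer. Taking compound 3 as the anchor and compound 2 as a pointer, compound 4 is expected to give a lower number, a 3.4-fold lower number from compound 3 to compound 4 (0.53 log units; beyond the scatter), beyond the scatter. The estimate for compound 4 in this assay is 70 10^-6 cm/s, with a range of 25 10^-6 cm/s to 200 10^-6 cm/s.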

Compound 4, apparent permeability: 23 10^-6 cm/s
Beside the measured number, compound 4's estimate is 3.0-fold (0.48 log units) above it; measured number below the stated range.
By their numbers in this assay, from the lowest: compounds 2 and 4 (each within the scatter of the next); then compounds 3 and 1 (each within the scatter of the next).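

At this aromatic carbon the number in this assay clearly depends on the group: a 10-fold lower number from compound 3 to compound 4 (1.01 log units; beyond the scatter) and a 14-fold lower number from compound 1 to compound 4 (1.14 log units; beyond the scatter) contrast with a 1.3-fold lower number from compound 1 to compound 3 (0.13 log units; within the scatter) for the earlier exchange. With 4-cyanobenzyl on the core, the exchange at the saturated chain carbon gives no change at the digits printed from compound 2 to compound 4 (within the scatter) and so does not separate furan-2-yl from 2-hydroxy-3-methoxyphenyl in this pair. No measurement at hand bears on the cause of the large steps.

On these data alone, it remains open whether the nitrile or the benzyl carbon link accounts for these steps; a plain benzyl or a 4-cyanophenyl group at this aromatic carbon would separate the two. As far as these compounds go, it is also open whether the same exchange at the chain carbon would stay within the scatter with 4-(tert-butyl)phenyl or 4-fluorophenoxy on the core.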